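The compounds below may be only part of what the source reports. "The series", "measured", "known", "first", "only" and "open" are said of these compounds alone.

Measured so far:
compound 1 `CCOC(=O)c1sc(-c2cccc(NC(=O)c3ccc(C(C)(C)C)cc3)c2)nc1Nc1ccc(N2CCN(C)CC2)cc1`: 4.22%
compound 2 `CCOC(=O)c1sc(-c2cccc(NC(=O)c3ccc(Cl)cc3)c2)nc1Nc1ccc(N2CCN(C)CC2)cc1`: 24.3%

In a functional assay on Raji cells (Homo sapiens) for antiproliferative activity, read by CCK-8 assay, with a stated time of 72 h, tested at 40 uM (a higher number here means more inhibition at the concentration tested (going by the name of the read-out), a lower number less inhibition), compound 2 gives 24.3%, the higher of the two numbers; compound 1 gives 4.22%. For the measured compounds named here, the only measured step, a number 20.1 percentage points higher from compound 1 to compound 2 (beyond the scatter), concerns the same aromatic carbon. Compound 3 `CCOC(=O)c1sc(-c2cccc(NC(=O)c3ccc(C#N)cc3)c2)nc1Nc1ccc(N2CCN(C)CC2)cc1` differs from compound 2 by cyano in place of chloro on an aromatic carbon. Going by the values given here, no measured pair exchanges chloro for cyano, so the one step gives only a loose guide; the expected step in this assay is a number 2.3 percentage points lower from compound 2 to compound 3 (within the scatter), within the scatter. Compound 3 is thus estimated at 22%, in the range 5% to 40%.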

Compound 3, a percentage reported as inhibition, at one concentration (the size of the read-out at that concentration, not a potency): 79.1%
The estimate for compound 3 lay 57.1 percentage points below the measured number, and the stated range ends below it.
By their numbers in this assay, from the lowest: compound 1; then compound 2; then compound 3.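

On the aromatic carbon para to a large group, the outcome in this assay depends far more on the group than the earlier pair indicated: cyano in place of chloro gives a number 54.8 percentage points higher from compound 2 to compound 3 (beyond the scatter). Cyano in place of tert-butyl gives a number 74.9 percentage points higher from compound 1 to compound 3 (beyond the scatter), so the three groups now fall in the order tert-butyl, chloro, cyano. Nothing measured here explains the size of these steps. Still open, from the compounds shown here alone, is whether the large gain is peculiar to cyano or is shared by other groups on this carbon, such as an amine, a carboxylic acid or trifluoromethyl.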